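A few compounds are considered here, and "the series" means these few. Any claim that something is new, unique, unknown or untested is made for them only; others in the source may bear on it.

Measured in an ADME assay on Left cardiac atrium (Cavia porcellus) (on this read-out higher numbers stand for an effect only at larger amounts of compound and lower numbers for an effect already at smaller amounts), so far:
compound 1 `CCOC(=O)C1=C(C)NC(C)=C(C(=O)OCC)C1c1c(-c2ccccc2F)nc2sccn12`: 5150 nM
compound 2 `CCOC(=O)C1=C(C)NC(C)=C(C(=O)OCC)C1c1c(-c2ccc(F)cc2)nc2sccn12`: 64 nM

In this assay, going by the values given here, compound 2 gives 64 nM, the lowest of the two numbers; the one measured step, an 80-fold lower number from compound 1 to compound 2 (1.91 log units; beyond the scatter), concerns the fluorophenyl substituent. Compound 3 `CCOC(=O)C1=C(C)NC(C)=C(C(=O)OCC)C1c1c(-c2ccc(F)cc2)nc2sc(Cl)cn12` differs from compound 2 by chloro in place of hydrogen on an aromatic carbon. Among the compounds with values here, no measured step touches the five-membered ring, so the fluorophenyl step offers no guide here and no change beyond the scatter is assumed. Compound 3 is therefore estimated at 80 nM, range 20 nM to 320 nM. The expected step is a 1.3-fold higher number from compound 2 to compound 3 (0.10 log units; within the scatter).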

Compound 3, half-maximal effective concentration: 49 nM
For compound 3 the middle estimate is 1.6-fold (0.21 log units) above the measured one, and the stated range covers the measured number.
By their numbers in this assay, from the lowest: compounds 3 and 2 (each within the scatter of the next); then compound 1.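

The step of a 1.3-fold lower number from compound 2 to compound 3 (0.12 log units; within the scatter) in this assay shows that the aromatic carbon next to the ring sulfur takes chloro in place of hydrogen without a change beyond the scatter. Going by these compounds alone, this is the first reading at this position, and that step is much smaller than an 80-fold lower number from compound 1 to compound 2 (1.91 log units; beyond the scatter) on the fluorophenyl substituent. Nothing available accounts for the step at this position.

From the compounds shown here alone, whether an amine, a carboxylic acid or a longer chain on this carbon would also leave the number within the scatter remains open. Going by these compounds, it is also open whether chloro here would give a similar step with the 2-fluorophenyl group of compound 1.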